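Removing a tert-Butyl Group from an Aryl Butenoic Acid

The compounds below may be only part of what the source reports. "The series", "measured", "known", "first", "only" and "open" are said of these compounds alone.

Of the compounds shown here, three sharing one core have been measured in a functional assay on K562 cells (Homo sapiens) for inhibition, read by MTT assay, with a stated time of 72 h; a lower number here means a stronger inhibitor, a higher number a weaker inhibitor. Compound 1 `Cc1cc(C2CCCCC2)c(C)cc1C(=O)/C=C/C(=O)O` gives 4240 nM in this assay. Compound 2 `CC(C)(C)c1ccc(C(=O)/C=C/C(=O)O)cc1` gives 4330 nM, which is the second highest of the three numbers, yet its gap to compound 1 lies within the scatter, so the two cannot be told apart. Compound 3 `O=C(O)/C=C/C(=O)c1ccc(Cl)c(Cl)c1` gives 23200 nM, a number well beyond the scatter above that of compound 2 and the highest of the set.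

Compound 4 `O=C(O)/C=C/C(=O)c1ccccc1` has not yet been measured. It differs from compound 2 by hydrogen in place of tert-butyl on an aromatic carbon: the tert-butyl group leaves and a hydrogen atom enters on an aromatic carbon of the six-membered aromatic ring of carbon only.

Within the data shown here, no pair of measured compounds shows the effect of taking such a group away, so the expectation rests on the spread of the three numbers. Compound 1 and compound 2 both carry a bulky carbon group on the ring and give close numbers, while compound 3, with chlorines instead, gives the highest number. The step from compound 2 to compound 4 is therefore estimated as a 3.0-fold higher number from compound 2 to compound 4 (0.48 log units; beyond the scatter), a rise beyond the scatter toward weaker inhibition. The number for compound 4 is expected to be around 13000 nM, with a likely range from 4500 nM to 40000 nM.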

Compound 4, half-maximal inhibitory concentration: 30200 nM
Estimate against measurement, compound 4: 2.3-fold (0.37 log units) below; measured number inside the range.
By their numbers in this assay, from the lowest: compounds 1 and 2 (each within the scatter of the next); then compounds 3 and 4 (each within the scatter of the next).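

Among these compounds, replacing tert-butyl with hydrogen in this assay produces a 7.0-fold higher number from compound 2 to compound 4 (0.84 log units; beyond the scatter) and so gives the first direct reading of what a group on this aromatic carbon, para to a group of 7 heavy atoms, is worth. The step lies beyond the scatter, so within this pair the compound carrying tert-butyl is the stronger inhibitor and the compound with only hydrogen at that carbon is the weaker one. Nothing available explains why removing these 4 carbon atoms has this effect.

Going by these compounds, whether a methyl group, an ethyl group or an amine on this same carbon would give a number close to that of compound 2 or close to that of compound 4 remains open, so the pair does not show how much of the carbon group is needed. Also open is whether the same change would give a step of similar size on a ring that carries other groups as well, since this is the only such pair shown.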